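The compounds below may be only part of what the source reports. "The series", "measured", "known", "first", "only" and "open" are said of these compounds alone.

In an assay on cells for inhibition of Amine oxidase [flavin-containing] B (Homo sapiens), read by fluorescence and spectrophotometry, using microsomes, with a stated time of 20 min (a higher number here means a weaker inhibitor, a lower number a stronger inhibitor), three compounds have been measured. Compound 1 `NS(=O)(=O)c1cccc(-c2nnc(-c3ccc(F)cc3)o2)c1` gives 975 nM. Compound 2 `NS(=O)(=O)c1cccc(-c2nnc(-c3ccc(Cl)cc3)o2)c1` gives 210 nM. Compound 3 `NS(=O)(=O)c1ccc(-c2nnc(-c3ccc(Cl)cc3)o2)cc1` gives 48 nM, the lowest of the three, with compound 2 nearest to it and compound 1 furthest away. Compound 2 and compound 3 share the same atoms joined differently, and the difference between the two cores is not broken down here.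

One structural change occurs twice among these compounds. Between compound 2 and compound 1 it reads fluoro in place of chloro on an aromatic carbon and it produced a 4.6-fold higher number from compound 2 to compound 1 (0.67 log units; beyond the scatter). Compound 4 `NS(=O)(=O)c1ccc(-c2nnc(-c3ccc(F)cc3)o2)cc1` has not yet been measured in this assay; it differs from compound 3 by fluoro in place of chloro on an aromatic carbon, which is the same change at the same kind of place.

For compound 4 the expected step is a 4.6-fold higher number from compound 3 to compound 4 (0.66 log units; beyond the scatter), a loss in potency of about the same size, and this expectation rests on the step of a 4.6-fold higher number from compound 2 to compound 1 (0.67 log units; beyond the scatter) seen with the other core. On that basis compound 4 is estimated to give 220 nM in this assay, with a likely range from 100 nM to 500 nM.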

Compound 4, half-maximal inhibitory concentration: 79 nM
Estimate against measurement, compound 4: 2.8-fold (0.44 log units) above, outside the stated range (below it).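

In this assay, going from 4-chlorophenyl to 4-fluorophenyl gave a 1.6-fold higher number from compound 3 to compound 4 (0.22 log units; within the scatter), a much smaller step than the one seen on the other core. The change therefore did not carry over in size from one core to the other, and a step measured on one core was a poor guide to the step on the other: the same change on two cores in this assay, a 4.6-fold higher number (0.67 log units; beyond the scatter) from compound 2 to compound 1 and a 1.6-fold higher number (0.22 log units; within the scatter) from compound 3 to compound 4, 2.8-fold (0.45 log units) apart, beyond the scatter of two such steps

This does not show why the two steps differ, and two pairs cannot say which of them would be more typical of any further core in the series. Nor does it establish a real loss on the core of compound 3, where the step stays within the scatter.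

Going by these compounds, only chloro and fluoro appear at this place, so it remains open how a methyl, a methoxy or a nitrile there would behave, and whether the gap between the cores would persist with those groups. Also open, on these data alone, is how a carboxylic acid or an amide would compare with the sulfonamide that all four compounds carry.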